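The source may hold more compounds than are shown below. What is called first, only, known or untested is meant among the compounds shown, and "the series" means these compounds.

Measured so far in an ADME assay on Huh-5-2 cells (Homo sapiens) for cytotoxicity; on this read-out higher numbers stand for lower toxicity in this test and lower numbers for higher toxicity in this test:

- Compound 1, `Cc1ccc(C#Cc2nc(C(N)=O)nn2COCCO)cc1`: compound 1 gives > 50 ug/mL, a limit of the assay.
- Compound 2, `NC(=O)c1nc(C#Cc2ccc(F)cc2)n(COCCO)n1`: compound 2 gives > 50 ug/mL, a limit of the assay.
- Compound 3, `NC(=O)c1nc(C#CC2(O)CCCC2)n(COCCO)n1`: compound 3 gives > 50 ug/mL, a limit of the assay.

Compound 3 therefore stands only at a limit in this assay, and the two other values of the series are limits as well, as the limit of > 50 ug/mL in this assay, at which 3 of the 3 values shown sit, shows. None of the steps among the measured compounds can be read: the step that the two limits leave unreadable from compound 1 to compound 2, the step that the two limits leave unreadable from compound 1 to compound 3 and the step that the two limits leave unreadable from compound 2 to compound 3 are all left unreadable by the limits on both sides.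

Compound 4, `NC(=O)c1nc(C#CC2(O)CCCCC2)n(COCCO)n1`, differs from compound 3 by 1-hydroxycyclohexyl in place of 1-hydroxycyclopentyl on a triple-bonded carbon. For the measured compounds named here, the steps that bear on it, a step that the two limits leave unreadable from compound 2 to compound 3 and a step that the two limits leave unreadable from compound 1 to compound 3, exchange the group on the triple-bonded carbon and both remain unreadable, so no step beyond the scatter is expected in this assay for the change from compound 3 to compound 4. For compound 4 the expected step is a number no higher from compound 3 to compound 4 (the limit leaves the size open). Compound 4 is estimated to give about 50 ug/mL in this assay, in the range 25 ug/mL to 100 ug/mL, most likely again reported as a limit.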

Compound 4, half-maximal cytotoxic concentration: > 50 ug/mL
Compound 4 ended at the assay's limit (the forecaster's own chance of this, stated with the estimate: 85%); the middle value sits exactly at the limit.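

Compound 4 also sits at a limit, so its steps to compound 1, compound 2 and compound 3 cannot be read in this assay: the limit of > 50 ug/mL in this assay, at which 4 of the 4 values shown sit. The compounds shown leave open where the actual value of each lies, and whether any exchange on the triple-bonded carbon changes it.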